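Compound 3 to compound 4: one methyl changes place

This account rests on a few compounds, and the source may have more. Where it says the series, first, only, none or still open, it means among the compounds named here.

Measured compounds in an ADME assay on Caco-2 cells (Homo sapiens) for permeability, in the apical to basolateral direction, at pH 7.4; a higher number here means that the compound crosses the layer faster, a lower number that the compound crosses the layer more slowly

compound 1 `O=C(N[C@H]1CN(S(=O)(=O)c2ccccc2)C[C@@H]1C(=O)N[C@H]1CCCNC1)c1cc(-c2ccccc2Cl)on1` gives 0.31 10^-6 cm/s
compound 2 `O=C(N[C@H]1CN(S(=O)(=O)c2ccccc2)C[C@@H]1C(=O)N1C[C@H]2CCNC[C@H]21)c1cc(-c2ccccc2Cl)on1` gives 0.53 10^-6 cm/s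
compound 3 `CN(C(=O)[C@H]1CN(S(=O)(=O)c2ccccc2)C[C@@H]1NC(=O)c1cc(-c2ccccc2Cl)on1)[C@H]1CCCNC1` gives 0.11 10^-6 cm/s

The series shows a 2.8-fold lower number from compound 1 to compound 3 (0.45 log units; beyond the scatter) and a 4.8-fold lower number from compound 2 to compound 3 (0.68 log units; beyond the scatter), which leaves compound 3 lowest of the three. Compound 4 `CN1CCC[C@H](NC(=O)[C@H]2CN(S(=O)(=O)c3ccccc3)C[C@@H]2NC(=O)c2cc(-c3ccccc3Cl)on2)C1` has the same atoms as compound 3 joined differently, with a group of 8 heavy atoms (6 carbon, 2 nitrogen; one six-membered non-aromatic ring with 1 hetero atom) in place of a group of 8 heavy atoms (6 carbon, 2 nitrogen; one six-membered non-aromatic ring with 1 hetero atom), on a carbonyl carbon as the change. The group that enters is (1-methylpiperidin-3-yl)amino. Compound 4 therefore has hydrogen on the amide-type nitrogen, like compound 1, where compound 3 has methyl. The closest guide is a 2.8-fold lower number from compound 1 to compound 3 (0.45 log units; beyond the scatter), a measured step that this change may largely reverse. A second guide is a 1.7-fold higher number from compound 1 to compound 2 (0.23 log units; within the scatter), a swap of the group on the same carbonyl carbon. For the measured compounds named here, no measured compound shows what the new methyl does on its own. The expected result is a 3.2-fold higher number from compound 3 to compound 4 (0.50 log units; beyond the scatter), an estimated rise that brings compound 4 back near compound 1. In this assay compound 4 is estimated at 0.35 10^-6 cm/s with a range from 0.14 10^-6 cm/s to 0.9 10^-6 cm/s expected around it.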

Compound 4, apparent permeability: 1.3 10^-6 cm/s
Compound 4: middle estimate off by 3.7-fold (0.57 log units), on the low side; measured number outside the range, above it.
By their numbers in this assay, from the lowest: compound 3; then compounds 1 and 2 (each within the scatter of the next); then compound 4.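

In this assay, for the compounds shown here, the same atoms give a 12-fold higher number from compound 3 to compound 4 (1.07 log units; beyond the scatter) when the methyl sits on the amine nitrogen in the ring and not on the amide-type nitrogen, so the place of this one methyl counts for far more than the earlier compounds could show. Adding that methyl to the ring nitrogen is itself a measurable change, with a 4.2-fold higher number from compound 1 to compound 4 (0.62 log units; beyond the scatter), which the earlier compounds could not reveal. With a 2.5-fold higher number from compound 2 to compound 4 (0.39 log units; beyond the scatter) as well, compound 4 now has the highest number of the four, beyond the scatter from each of the others.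

The data shown give no reason for any of these steps. Going by these compounds, it remains open whether only methyl does this on the ring nitrogen, or whether ethyl or a longer chain in the same place would give a similar number.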